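The compounds below may be only part of what the source reports. "The series", "measured", "known", "first", "only" and "open" are said of these compounds alone.

Measured in a functional assay on HepG2 cells (Homo sapiens) for antiproliferative activity, read by XTT assay, with a stated time of 72 h; on this read-out higher numbers stand for weaker inhibition and lower numbers for stronger inhibition:
Compound 1 `COc1ncnc2c1c(-c1ccccc1)cn2[C@@H]1O[C@H](CO)[C@@H](O)[C@H]1O`: > 20000 nM, a limit.
Compound 2 `C#Cc1cn([C@@H]2O[C@H](CO)[C@@H](O)[C@H]2O)c2ncnc(OC)c12`: 12700 nM.
Compound 3 `CSc1ncnc2c1c(-c1cccs1)cn2[C@@H]1O[C@H](CO)[C@@H](O)[C@H]1O`: > 20000 nM, a limit.

Compound 3 has no exact number on this scale, only the limit of > 20000 nM. That puts it with compound 1 in the group described by the limit of > 20000 nM in this assay, at which 2 of the 3 values shown sit. Compound 4 `C#Cc1cn([C@@H]2O[C@H](CO)[C@@H](O)[C@H]2O)c2ncnc(SC)c12` carries ethynyl in place of thiophen-2-yl on an aromatic carbon. For the measured compounds named here, one measured step bears on this change, since it also replaces an aromatic ring with ethynyl at that place, although the ring leaving there is phenyl. That step is an at least 1.5-fold lower number from compound 1 to compound 2 (0.19 log units; that floor lies within the scatter). It starts from a limit, so it gives only a floor on its size. A similar swap in this assay therefore points towards a lower number, meaning stronger inhibition, but the evidence is one pair and a modest shift is all it supports. The estimate amounts to an at least 2.0-fold lower number from compound 3 to compound 4 (0.30 log units; that floor lies within the scatter), which is an expected change and not a measured one. Compound 4 is expected at about 10000 nM, with an estimated range of 2500 nM to 20000 nM.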

Compound 4, half-maximal inhibitory concentration: > 15000 nM
Compound 4: no number, only a limit (the forecaster's own chance of this, stated with the estimate: 30%); middle value at least 1.5-fold (0.17 log units) away from the limit.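

In this assay compound 4 gives > 15000 nM, which is a limit, so ethynyl at this position yields no exact number when methylsulfanyl sits on the core. Compound 3 and compound 4 both stand at limits and the step between them cannot be read, which leaves the change from thiophen-2-yl to ethynyl without a measured size in this series. With ethynyl held in place, methylsulfanyl in place of methoxy gives an at least 1.1-fold higher number from compound 2 to compound 4 (0.07 log units; that floor lies within the scatter), so this swap shows no clear effect, and compound 2 remains the only compound shown with an exact number.

Going by these compounds, it remains open whether the gain hinted at by the phenyl-to-ethynyl step holds on a methylsulfanyl core. On these data alone, it is also open how a different group at this position, such as an amine or a longer alkyne chain, would read.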